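The compounds below may be only part of what the source reports. "The series", "measured", "known", "first", "only" and "open" are said of these compounds alone.

Measured so far:
- compound 1, `Cc1csc(-c2cccc(CNc3ccc4[nH]nc(C(=O)O)c4c3)c2O)n1`: 23 nM
- compound 2, `O=C(O)c1nnsc1Sc1ccc(Cl)cc1`: > 30000 nM
- compound 3, `CC(C)c1csc(-c2cccc(CN(C)c3ccc4[nH]nc(C(=O)O)c4c3)c2)n1`: 710 nM

These numbers come from an assay on isolated protein for inhibition of 2-Hydroxyacid oxidase 1 (Homo sapiens), with stated times of 30 min and 15 min; a lower number here means a stronger inhibitor, a higher number a weaker inhibitor. Compound 1 holds the lower of the two numbers given; compound 3 sits higher by a gap beyond the usual scatter. For compound 2 the result is only a limit of the assay, (the limit of > 30000 nM in this assay, at which 1 of the 3 values shown sits), not a number.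

Compound 4, `CC(C)c1coc(-c2cccc(CNc3ccc4[nH]nc(C(=O)O)c4c3)c2O)n1`, has not been measured. It differs from compound 1 in one place: 4-isopropyl-1,3-oxazol-2-yl in place of 4-methyl-1,3-thiazol-2-yl on an aromatic carbon.

Within the data shown here, no single-change step between measured compounds is available to anchor this exchange, so a small step is expected, within or just beyond the scatter, leaning toward a weaker inhibitor. Compound 4 is expected to give 45 nM, with a range from 12 nM to 170 nM, a step of a 2.0-fold higher number from compound 1 to compound 4 (0.29 log units; within the scatter).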

Compound 4, half-maximal inhibitory concentration in the 2-Hydroxyacid oxidase 1 assay: 87 nM
Estimate against measurement, compound 4: 1.9-fold (0.29 log units) below, within the range that was stated.
By their numbers in the 2-Hydroxyacid oxidase 1 assay, from the lowest: compound 1; then compound 4; then compound 3. At a limit, above all of these: compound 2.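

Exchanging 4-methyl-1,3-thiazol-2-yl for 4-isopropyl-1,3-oxazol-2-yl on this aromatic carbon weakens inhibition, with a 3.8-fold higher number from compound 1 to compound 4 (0.58 log units; beyond the scatter). In a physicochemical assay for solubility, measured as kinetic solubility, at pH 7.4 (a higher number here means a more soluble compound, a lower number a less soluble compound), compound 1 gives 44000 nM and compound 4 gives 229000 nM. Inhibition and solubility therefore move in opposite directions with this one exchange, so the weaker inhibitor is the more soluble compound: the measured solubility of compound 1, 44000 nM, and of compound 4, 229000 nM, a 5.2-fold higher number (0.72 log units; beyond the scatter)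

The exchange alters both the ring and its alkyl group, so the compounds shown cannot separate the two. As far as these compounds go, a 4-methyl-1,3-oxazol-2-yl group at this position would change the ring alone, and its effect remains open.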